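A few compounds are considered here, and "the series" means these few. Any claim that something is new, unique, unknown or untested is made for them only; others in the source may bear on it.

Measured compounds:
compound 1, `CCn1ccc2cc(NC(=O)CN(c3cc(Cl)ccc3OC)S(=O)(=O)c3ccccc3)ccc21`: 2220 nM
compound 2, `COc1ccc(Cl)cc1N(CC(=O)N1CCCCC1)S(=O)(=O)c1ccccc1`: 14500 nM

Both numbers come from a functional assay on SH-SY5Y cells (Homo sapiens), read by MTT assay, with a stated time of 24 h; a higher number here means that more compound is needed for the effect, a lower number that less compound is needed. Compound 2 stands at the higher of the two numbers; compound 1 sits lower, and the gap between them lies beyond the usual scatter. Among the compounds with values here, no pair in this set differs in a single place, so the two values can only be set side by side, not read as a step.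

Compound 3, `COc1ccc(Cl)cc1N(CC(=O)Nc1ccc(Cl)cc1)S(=O)(=O)c1ccccc1`, is not yet measured in this assay. It differs from compound 2 in one place: (4-chlorophenyl)amino in place of piperidin-1-yl on a carbonyl carbon. The change brings in a hydrogen-bond donor and an aromatic ring at the carbonyl, features that compound 1 also bears at its carbonyl, whereas compound 2 has none there. Without a measured step for this change, the expectation rests on the two values alone and points toward compound 1. The step of a 4.1-fold lower number from compound 2 to compound 3 (0.62 log units; beyond the scatter) is expected to go to a lower number and to exceed the scatter. For compound 3 the estimated value in this assay is 3500 nM, with a range from 1200 nM to 11000 nM.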

Compound 3, half-maximal effective concentration: > 20000 nM
Compound 3 gave a limit, no number; the forecaster's own chance of this, stated with the estimate: 5%; middle value at least 5.7-fold (0.75 log units) from the limit.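

In this assay compound 3 gives a limit, not a number: the limit of > 20000 nM in this assay, at which 1 of the 3 values shown sits. Going by these compounds, at the carbonyl, (4-chlorophenyl)amino in place of piperidin-1-yl gives an at least 1.3-fold higher number from compound 2 to compound 3 (0.13 log units; that floor lies within the scatter), so an amide hydrogen with an aromatic ring at this carbonyl brings no lowering, while the size of any rise stays unknown. On the amide-type nitrogen, 4-chlorophenyl in place of 1-ethyl-1H-indol-5-yl gives an at least 9.0-fold higher number from compound 1 to compound 3 (0.95 log units; beyond the scatter), so the lower number of compound 1 goes with the 1-ethyl-1H-indol-5-yl group and not with the amide hydrogen alone.

The compounds shown leave open whether that lower number needs the whole 1-ethyl-1H-indol-5-yl group or only part of it. A plain phenyl or a pyridinyl on the amide-type nitrogen would show how much the chlorine of compound 3 counts.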